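The source may hold more compounds than are shown below. What is called first, only, known or untested is meant among the compounds shown, and "the series" means these compounds.

Measured so far:
Compound 1, `CN(C)CCCCCCCOc1ccc2oc(-c3ccccc3)cc(=O)c2c1`, in an assay on isolated protein (Cavia porcellus) with Sigma non-opioid intracellular receptor 1 (Homo sapiens) as the target, read by radioligand binding (a lower number here means a stronger inhibitor, a higher number a weaker inhibitor), gives 165 nM.
Compound 2, `O=c1cc(-c2ccccc2)oc2ccc(OCCCN3CCC(O)CC3)cc12`, in this assay gives 130 nM.

Compound 2 holds the lowest of the two numbers, but its nearest neighbour, compound 1, sits within the scatter of it, so the two are not separable: the step of a 1.3-fold lower number from compound 1 to compound 2 (0.10 log units; within the scatter) says as much.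

The compound not yet measured is compound 3, `O=c1cc(-c2ccccc2)oc2ccc(OCCCCCCN3CCC(O)CC3)cc12`. It differs from compound 2 in one place: 3-(4-hydroxypiperidin-1-yl)propyl in place of 4-hydroxypiperidin-1-yl on a saturated chain carbon, three bonds along the chain from an oxygen on an aromatic ring. In effect the basic ring is carried further out from the aryl oxygen on a longer saturated chain.

Within the data shown here, only one measured step exists, from compound 1 to compound 2, and it changes the amine end and the chain together, so it bears on the present step only loosely. It shows that a long chain ending in an amine (compound 1) and a short chain ending in a 4-hydroxypiperidin-1-yl (compound 2) give numbers within the scatter of each other. Among the measured compounds shown here, no step isolates chain length alone.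

On that basis no change beyond the scatter is expected, a 1.1-fold lower number from compound 2 to compound 3 (0.03 log units; within the scatter). Compound 3 is therefore estimated at 120 nM, with a range from 45 nM to 320 nM.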

Compound 3, half-maximal inhibitory concentration: 100 nM
Compound 3: middle estimate off by 1.2-fold (0.08 log units), on the high side; low and high end bracket the measured number.
By their numbers in this assay, from the lowest: compounds 3, 2 and 1 (each within the scatter of the next).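

In this assay, among these compounds, the step from 4-hydroxypiperidin-1-yl to 3-(4-hydroxypiperidin-1-yl)propyl gives a 1.3-fold lower number from compound 2 to compound 3 (0.11 log units; within the scatter) and is the first comparison here in which the chain grows while the amine end stays the same, so the longer chain leaves the number inside the scatter at this position. The second new comparison concerns the chain end instead: with 4-hydroxypiperidin-1-yl in place of (dimethylamino)methyl on a saturated chain carbon, six bonds along the chain from an oxygen on an aromatic ring, the result is a 1.7-fold lower number from compound 1 to compound 3 (0.22 log units; within the scatter) and this exchange is likewise not separable from the scatter. Nothing available offers a measured explanation for either result.

The compounds shown leave open whether a chain of two carbons, or one much longer than that of compound 3, would shift the number beyond the scatter. They also leave open what the hydroxyl contributes, a question that a plain piperidin-1-yl or a morpholin-4-yl at the chain end could address, and whether a group other than phenyl on the shared core would matter more than anything at the chain end.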